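Replacing the distal aryl of compound 2 with a carbamoyl group

This account rests on a few compounds, and the source may have more. Where it says the series, first, only, none or still open, it means among the compounds named here.

Measured so far:
compound 1 `CCc1ccc(-c2ccc(NC3=CC(=O)c4ncncc4C3=O)cc2)cc1`: 3100 nM
compound 2 `COc1ccc(-c2ccc(NC3=CC(=O)c4ncncc4C3=O)cc2)cc1`: 3500 nM
compound 3 `O=C1C=CC(=O)c2ncncc21`: 19400 nM

Of the compounds shown here, three have been tested in a functional assay on BXPC-3 cells (Homo sapiens) for cytotoxicity, read by MTT assay, with a stated time of 72 h; on this read-out lower numbers stand for stronger inhibition and higher numbers for weaker inhibition. Compound 1 gives 3100 nM, compound 2 gives 3500 nM and the bare core, compound 3, gives 19400 nM. Compound 2 thus stands second highest of the three numbers, nearest to compound 1 and furthest from compound 3, whose number is beyond the scatter above it. Among the measured compounds shown here, the only step between measured neighbours, a 1.1-fold higher number from compound 1 to compound 2 (0.05 log units; within the scatter), is within the scatter.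

The unmeasured compound 4 `NC(=O)c1ccc(NC2=CC(=O)c3ncncc3C2=O)cc1` differs from compound 2 in one place:
carbamoyl in place of 4-methoxyphenyl on an aromatic carbon

For the measured compounds named here, no measured step touches this kind of change: the one step known swaps two small groups on the outer ring and left the number essentially unchanged, whereas here the whole outer ring leaves. Compound 3, lacking the entire anilino arm, sits far higher than compound 2, so the author expects compound 4 to land between the two, with a step of a 2.0-fold higher number from compound 2 to compound 4 (0.30 log units; within the scatter) towards a higher number. Compound 4 is estimated at 7000 nM, within 2500 nM to 20000 nM.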

Compound 4, half-maximal inhibitory concentration: > 10000 nM
Compound 4: only a limit was reported (the forecaster's own chance of this, stated with the estimate: 10%); at least 1.4-fold (0.15 log units) between middle value and limit.
By their numbers in this assay, from the lowest: compounds 1 and 2 (each within the scatter of the next); then compound 3.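

In this assay compound 4 carries only a limit, > 10000 nM, not a number. Even so, this position responds to the change where the swap of ethyl for methoxy on the outer ring did not: carbamoyl in place of 4-methoxyphenyl gives an at least 2.8-fold higher number from compound 2 to compound 4 (0.45 log units; beyond the scatter), and carbamoyl in place of 4-ethylphenyl gives an at least 3.2-fold higher number from compound 1 to compound 4 (0.50 log units; beyond the scatter). Both steps therefore fix only a smallest size, and the full size remains unknown: the limit of > 10000 nM in this assay, at which 1 of the 4 values shown sits.

The compounds shown leave open whether the higher number goes with the departure of the outer ring or with the carbamoyl group itself. A carboxylic acid, an amine or a short alkyl chain on this aromatic carbon, or a different outer ring kept in place, could separate the two.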